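This account rests on a few compounds, and the source may have more. Where it says the series, first, only, none or still open, it means among the compounds named here.

In an ADME assay on Vero cells (Chlorocebus sabaeus) for cytotoxicity, with a stated time of 72 h (on this read-out higher numbers stand for weaker inhibition and lower numbers for stronger inhibition), compound 1 `CCOC(=O)c1cc(/C=C/c2ccccc2)on1` has no single number, and its entry reads "not determined" (no result reported). Compound 2 `CCOC(=O)c1cc(/C=C/c2ccccc2C(F)(F)F)on1` is no different, with an entry of "not determined" (no result reported). Compound 3 `CCOC(=O)c1cc(/C=C/c2ccccc2CC)on1` gives > 128000 nM, which is a limit of the assay and not a number. The next compound, compound 4 `CCOC(=O)c1cc(/C=C/c2cccc(C(C)C)c2)on1`, departs from compound 1 by one change, (isopropyl in place of hydrogen on an aromatic carbon), with isopropyl in place of hydrogen on an aromatic carbon, meta to a large group. For the measured compounds named here, no measured step shows the size of such a change in this assay, so no step beyond the scatter is expected, and the limit for compound 3 remains the only guide. For compound 4 the estimated value is 120000 nM, with an expected range from 40000 nM to 260000 nM.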

Compound 4, half-maximal inhibitory concentration: > 128000 nM
Compound 4: only a limit was reported; the forecaster's own chance of this, stated with the estimate: 70%; at least 1.0-fold (0.02 log units) between middle value and limit.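

No step can be read between compound 1, which has no single number, and compound 4, whose entry is only a limit. The compounds shown leave open what size of change isopropyl brings in this assay.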